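The source may hold more compounds than are shown below. What is called first, only, known or untested is meant among the compounds shown, and "the series" means these compounds.

Measured compounds in an assay on CHO-K1 cells for displacement of a labelled ligand from prostaglandin E2 receptor EP1 subtype (Homo sapiens); on this read-out higher numbers stand for weaker inhibition and lower numbers for stronger inhibition:
compound 1 `Cc1cc(C(N)=O)nn1Cc1cc(Cl)ccc1OCc1ccccc1`: 126 nM
compound 2 `Cc1cc(C(=O)Nc2cccc(F)c2)nn1Cc1cc(Cl)ccc1OCc1ccccc1`: 200 nM

Among the measured compounds shown here, compound 2 stands highest of the two numbers in this assay, with compound 1 as its only neighbour; the step of a 1.6-fold higher number from compound 1 to compound 2 (0.20 log units; within the scatter) lies within the scatter, so the two compounds cannot be ordered on these data.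

Compound 3 `Cc1cc(C(=O)Nc2ccc(F)cc2)nn1Cc1cc(Cl)ccc1OCc1ccccc1` differs from compound 2 by 4-fluorophenyl in place of 3-fluorophenyl on an amide-type nitrogen. For the measured compounds named here, no measured step exchanges one fluorophenyl for another, so none bears on this change directly. Going by the values given here, the only step touching the amide-type nitrogen, a 1.6-fold higher number from compound 1 to compound 2 (0.20 log units; within the scatter), introduced the fluorophenyl group in the first place and stayed within the scatter. Nothing in the series therefore points to a shift beyond the scatter in this assay, in either direction.

Compound 3 is expected near 200 nM, with a range from 90 nM to 450 nM. The step of no change at the digits printed from compound 2 to compound 3 (within the scatter) is thus expected to remain within the scatter.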

Compound 3, half-maximal inhibitory concentration: 79.4 nM
Beside the measured number, compound 3's estimate is 2.5-fold (0.40 log units) above it; the measured number lies below the stated range.
By their numbers in this assay, from the lowest: compounds 3, 1 and 2 (each within the scatter of the next, the first and the last beyond it).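

In this assay, the amide-type nitrogen proves sensitive to the choice between the two fluorophenyl groups: a 2.5-fold lower number from compound 2 to compound 3 (0.40 log units; beyond the scatter), a modest step beyond the scatter with the same atoms joined differently, whereas the earlier change from hydrogen to 3-fluorophenyl stayed within it. With 4-fluorophenyl in place of the amide hydrogen, the result is a 1.6-fold lower number from compound 1 to compound 3 (0.20 log units; within the scatter), so each fluorophenyl amide reads level with the primary amide and only the two fluorophenyl isomers separate. No evidence here bears on why these isomers differ.

From the compounds shown here alone, it remains open whether this separation requires fluorine at all, which phenyl, 4-chlorophenyl or 4-methoxyphenyl on the same nitrogen would test. Going by these compounds, it is also open whether a carboxylic acid in place of the amide would keep these numbers.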